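The source may hold more compounds than are shown below. What is called first, only, known or untested is meant among the compounds shown, and "the series" means these compounds.

In a functional assay on PC-3 cells (Homo sapiens) for cytotoxicity, read by MTT assay, with a stated time of 72 h (on this read-out lower numbers stand for stronger inhibition and higher numbers for weaker inhibition), compound 1 `O=C(N/N=C/c1cccc(Br)c1)Nc1cc2c(Nc3ccc(F)c(Cl)c3)ncnc2cc1O[C@H]1CCOC1` gives 15500 nM, compound 2 `O=C(N/N=C/c1ccc(F)cc1Cl)Nc1cc2c(Nc3ccc(F)c(Cl)c3)ncnc2cc1O[C@H]1CCOC1` gives 28400 nM, and compound 3 `COc1cc2ncnc(Nc3ccc(F)c(Cl)c3)c2cc1NC(=O)N/N=C/c1ccc(F)cc1Cl` gives 25700 nM. Compound 3 lies within the scatter of both other compounds, so these numbers set no order among the three.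

Compound 4 `COc1cc2ncnc(Nc3ccc(F)c(Cl)c3)c2cc1NC(=O)N/N=C/c1cc(Br)c(O)c(Br)c1` differs from compound 3 at one place, with 3,5-dibromo-4-hydroxyphenyl in place of 2-chloro-4-fluorophenyl on a carbon with a double bond to nitrogen.

Going by the values given here, two measured steps bear on this change. The closer one is an exchange at the same place, 2-chloro-4-fluorophenyl in place of 3-bromophenyl, which gives a 1.8-fold higher number from compound 1 to compound 2 (0.26 log units; within the scatter). The other, methyl in place of oxolan-3-yl on an oxygen on an aromatic ring, lies elsewhere in the structure and gives a 1.1-fold lower number from compound 2 to compound 3 (0.04 log units; within the scatter). Neither step leaves the scatter. However, only one exchange at this place has been measured, and no measured compound carries 3,5-dibromo-4-hydroxyphenyl, so the evidence is thin.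

No step beyond the scatter is therefore expected in this assay, and no direction is favoured. The expected step is a 1.2-fold lower number from compound 3 to compound 4 (0.07 log units; within the scatter). For compound 4 the estimated value is 22000 nM, with an expected range from 9000 nM to 50000 nM.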

Compound 4, half-maximal inhibitory concentration: 41500 nM
Estimate against measurement, compound 4: 1.9-fold (0.28 log units) below; measured number inside the range.
By their numbers in this assay, from the lowest: compounds 1, 3, 2 and 4 (each within the scatter of the next, the first and the last beyond it).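

In this assay, replacing 2-chloro-4-fluorophenyl with 3,5-dibromo-4-hydroxyphenyl on the carbon with a double bond to nitrogen gives a 1.6-fold higher number from compound 3 to compound 4 (0.21 log units; within the scatter). The earlier exchange at this place involved only rings carrying halogens, whereas this one also brings in a hydroxyl group, with the hydrogen-bond donor and acceptor counted for it, and still does not leave the scatter, so this read-out does not separate these two substituted phenyl groups. Nothing available explains the size of this step or shows what the added hydroxyl group and the second bromine each contribute.

The compounds shown carry only substituted phenyl groups at this place, so it remains open whether an unsubstituted 4-hydroxyphenyl, a ring bearing an amine or a carboxylic acid, or a saturated group such as cyclohexyl would move the number beyond the scatter. From the compounds shown here alone, it is also open whether 3,5-dibromo-4-hydroxyphenyl would behave the same way on the oxolan-3-yl ether of compound 1 and compound 2 as it does on the methyl ether of compound 4.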